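This account rests on a few compounds, and the source may have more. Where it says the series, first, only, none or still open, it means among the compounds named here.

Series notes. Compound 1 `Fc1ccc([C@@H]2C[C@@H]3Cc4ccc5ccccc5c4N2O3)cc1` is examined in an ADME assay on THP-1 cells (Homo sapiens) for cytotoxicity, read by MTT assay, with a stated time of 72 h; a lower number here means that less compound is tolerated, a higher number that more compound is tolerated; in that assay compound 1 gives > 300000 nM, which is a limit of the assay rather than a number. Compound 2 `Brc1cccc([C@@H]2C[C@@H]3Cc4ccc5ccccc5c4N2O3)c1` gives > 250000 nM in this assay, again a limit. Among the measured compounds shown here, the one measured step, a step that the two limits leave unreadable from compound 1 to compound 2, therefore carries no readable size, because its two values sit at the limit of > 250000 nM in this assay, at which 1 of the 2 values shown sits, and (the limit of > 300000 nM in this assay, at which 1 of the 2 values shown sits). Compound 1 thus stands only at a limit on the numbers shown, and the one further value shown is also a limit.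

The unmeasured compound 3 `COc1cccc([C@@H]2C[C@@H]3Cc4ccc5ccccc5c4N2O3)c1` differs from compound 1 by 3-methoxyphenyl in place of 4-fluorophenyl on a saturated ring carbon. For the measured compounds named here, the only measured step that bears on this change is a step that the two limits leave unreadable from compound 1 to compound 2, and it shows no measurable difference between the two limits. Going by the values given here, no step reads as a size, so no step beyond the scatter is expected in this assay for the new change. For compound 3 the expected value is 300000 nM, with a range of 100000 nM to 1000000 nM. The expected step of a number no higher from compound 1 to compound 3 (the limit leaves the size open) is accordingly essentially none, and a limit rather than a number is the likelier outcome.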

Compound 3, half-maximal cytotoxic concentration: > 300000 nM
Compound 3: only a limit was reported (the forecaster's own chance of this, stated with the estimate: 80%); the middle value lies on the limit itself.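

In this assay compound 3 gives > 300000 nM, which is a limit and not a number. The steps linking compound 3 with compound 1 and compound 2 therefore cannot be read. The compounds shown leave open whether the 3-methoxyphenyl, 4-fluorophenyl and 3-bromophenyl compounds differ at all in this assay, and at what concentration any of them would reach a half-maximal cytotoxic effect.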